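This account rests on a few compounds, and the source may have more. Where it says the series, first, only, none or still open, it means among the compounds named here.

Compound 1 `CCOC(=O)[C@@H]1CCCN(S(=O)(=O)c2ccc(S(=O)(=O)N3CCOCC3)cc2)C1`: > 10000 nM
Compound 2 `CCN(CC)S(=O)(=O)c1ccc(S(=O)(=O)N2CCC[C@@H](C(=O)N3CCC(c4nc(C(C)C)no4)CC3)C2)cc1`: > 10000 nM

Both measured compounds were tested in a functional assay on MIA PaCa-2 cells (Homo sapiens) for inhibition, read by MTT assay, with a stated time of 3 days; on this read-out lower numbers stand for stronger inhibition and higher numbers for weaker inhibition. In this assay compound 1 gives > 10000 nM, which is a limit of the assay and not a number. For compound 2 this assay records > 10000 nM, again a limit. Among the measured compounds shown here, compound 1 therefore stands at the limit, and so does the only other value available: the limit of > 10000 nM in this assay, at which 2 of the 2 values shown sit.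

Compound 3 `CCOC(=O)[C@@H]1CCCN(S(=O)(=O)c2ccc(C(=O)N(CC)CC)cc2)C1`, not yet measured, differs from compound 1 in a single place: diethylcarbamoyl in place of (morpholin-4-yl)sulfonyl on an aromatic carbon. For the measured compounds named here, no pair of measured compounds shows how a change of this kind shifts potency, so the size of the step has to be guessed. Because compound 1 sits at the limit (the limit of > 10000 nM in this assay, at which 2 of the 2 values shown sit), no shift downward can be seen from the numbers, and a shift to stronger inhibition would need to be large to appear at all. The step that the limit leaves unreadable from compound 1 to compound 3 is therefore expected to be none beyond the scatter. Compound 3 is expected at 20000 nM, in a range from 5000 nM to 100000 nM, most likely reported once more as a limit.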

Compound 3, half-maximal inhibitory concentration: > 10000 nM
Compound 3: a limit, no number; the forecaster's own chance of this, stated with the estimate: 85%; the middle value does not contradict the limit.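

Compound 1 and compound 3 both stand at a limit of the assay and not at a number, so no step from one to the other can be read: the limit of > 10000 nM in this assay, at which 3 of the 3 values shown sit.

The compounds shown leave open how strongly any of them inhibits these cells, and whether diethylcarbamoyl in place of (morpholin-4-yl)sulfonyl changes potency at all.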